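The source may report more compounds than this note shows. Statements on the series, on what has been measured and on what is new or still open speak of the compounds shown alone.

Among the compounds with values here, compound 1 (`N#Cc1cccc(C(=O)Nc2ccc3nc(NC(=O)C4CCCCC4)sc3c2)c1`) gives 0.52 ug/mL in a functional assay on WI-38 VA13 cells (Homo sapiens) for cytotoxicity (on this read-out lower numbers stand for an effect already at smaller amounts and higher numbers for an effect only at larger amounts of compound), and holds the only actual number so far. Compound 2 (`O=C(Nc1ccc2nc(NC(=O)C3CCCCC3)sc2c1)c1cccc(Oc2ccccc2)c1`) reports only a limit (> 4 ug/mL). Compound 3 (`O=C(Nc1ccc2nc(NC(=O)C3CCCCC3)sc2c1)c1ccc(Br)cc1`) also reports only a limit (> 4 ug/mL). The two steps out of compound 1 end at the limit of > 4 ug/mL in this assay, at which 2 of the 3 values shown sit, and so give minimum sizes only.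

Compound 4 (`CC(=O)Nc1ccc2nc(NC(=O)C3CCCCC3)sc2c1`) is the next case: methyl in place of 3-cyanophenyl on a carbonyl carbon with methyl in place of 3-cyanophenyl on a carbonyl carbon. Within the data shown here, two measured steps bear on it. Replacing the same 3-cyanophenyl gave an at least 7.6-fold higher number from compound 1 to compound 3 (0.88 log units; beyond the scatter) and putting phenoxy in place of cyano gave an at least 7.6-fold higher number from compound 1 to compound 2 (0.88 log units; beyond the scatter) with both beyond the scatter. Neither step removes the aromatic ring of that group, so the precedent is only partial. A modest move to a higher number in this assay is expected, and a reading at the limit remains possible. The estimated step is a 4.8-fold higher number from compound 1 to compound 4 (0.68 log units; beyond the scatter) in that direction. For compound 4 the estimated value is 2.5 ug/mL with an expected range of 0.6 ug/mL to 8 ug/mL as its ends.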

Compound 4, half-maximal effective concentration: 2.7 ug/mL
The estimate for compound 4 lay 1.1-fold (0.03 log units) below the measured number; the range from low to high includes it.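

Methyl in place of 3-cyanophenyl on the carbonyl carbon gives the first step of full size out of compound 1 in this assay, with a 5.2-fold higher number from compound 1 to compound 4 (0.72 log units; beyond the scatter) and no limit involved. The aromatic ring of that group is therefore not needed for a measurable effect, though losing it moves the number away from that of compound 1. Methyl cannot be ranked against 4-bromophenyl, since the result is only an at least 1.4-fold lower number from compound 3 to compound 4 (0.17 log units; that floor lies within the scatter) and so shows no real difference between them.

Going by these compounds, it remains open whether the nitrile or the ring carrying it accounts for the gap to compound 1, and whether a longer chain such as propyl, an amine or a carboxylic acid on the carbonyl carbon would behave like methyl. On these data alone, the true sizes of the steps that end at the limit also stay unknown: the limit of > 4 ug/mL in this assay, at which 2 of the 4 values shown sit.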